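Chain extension from compound 3 to compound 4

A few compounds are considered here, and "the series" means these few. Any claim that something is new, unique, unknown or untested is made for them only; others in the source may bear on it.

Compound 1 `CCN1CCN(CCC(=O)Nc2nc3c(C)cccc3s2)CC1` is the shortest member of this set; in an assay on membranes from brain for displacement of a labelled ligand from Sigma non-opioid intracellular receptor 1 (Cavia porcellus), read by scintillation counting, with a stated time of 120 min (on this read-out higher numbers stand for weaker inhibition and lower numbers for stronger inhibition), compound 1 gives 543 nM. Compound 2 `CCCCN1CCN(CCC(=O)Nc2nc3c(C)cccc3s2)CC1` gives 204 nM in this assay, and a 2.7-fold lower number from compound 1 to compound 2 (0.43 log units; beyond the scatter). Compound 3 `Cc1cccc2sc(NC(=O)CCN3CCN(CCN(C)C)CC3)nc12` gives 1000 nM in this assay; this is the highest of the three numbers, with a 1.8-fold higher number from compound 1 to compound 3 (0.27 log units; within the scatter) and a 4.9-fold higher number from compound 2 to compound 3 (0.69 log units; beyond the scatter).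

Compound 4 `Cc1cccc2sc(NC(=O)CCN3CCN(CCCN(C)C)CC3)nc12` differs from compound 3 by (dimethylamino)methyl in place of dimethylamino on a saturated chain carbon, two bonds along the chain from an amine nitrogen in a ring. Among the compounds with values here, no measured step shows exactly this extension. The nearest guide is a 2.7-fold lower number from compound 1 to compound 2 (0.43 log units; beyond the scatter), where lengthening the chain gave a lower number, whereas a 4.9-fold higher number from compound 2 to compound 3 (0.69 log units; beyond the scatter), dimethylamino in place of ethyl, gave a higher one. Compound 4 keeps the dimethylamino end and only adds one chain carbon, so a small lowering of the number is expected, at or near the scatter, with the direction uncertain. Compound 4 is therefore estimated at 650 nM in this assay, with a range from 250 nM to 1600 nM. This corresponds to an expected step of a 1.5-fold lower number from compound 3 to compound 4 (0.19 log units; within the scatter).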

Compound 4, inhibition constant: 570 nM
The estimate for compound 4 lay 1.1-fold (0.06 log units) above the measured number; measured number inside the range.
By their numbers in this assay, from the lowest: compound 2; then compounds 1, 4 and 3 (each within the scatter of the next).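

In this assay, the extra chain carbon on the dimethylamino end gives a 1.8-fold lower number from compound 3 to compound 4 (0.24 log units; within the scatter), so the change from dimethylamino to (dimethylamino)methyl at this position cannot be separated from the scatter. The same holds for a 1.0-fold higher number from compound 1 to compound 4 (0.02 log units; within the scatter), whereas a 2.8-fold higher number from compound 2 to compound 4 (0.45 log units; beyond the scatter) stays beyond the scatter, so in this small set only compound 2 stands apart from compound 4 on this read-out. No measurement shown here accounts for these numbers.

Going by these compounds, whether a longer chain ending in dimethylamino would separate from compound 4 remains open. On these data alone, it is equally open whether a cyclic amine such as piperidine or morpholine, or a hydroxyl group, in place of dimethylamino would give a number closer to that of compound 2.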